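This account rests on a few compounds, and the source may have more. Where it says the series, first, only, none or still open, it means among the compounds named here.

Of the compounds shown here, two sharing one core have been measured in an ADME assay on MT2 cells (Homo sapiens) for cytotoxicity, read by MTT assay; on this read-out lower numbers stand for higher toxicity in this test and higher numbers for lower toxicity in this test. Compound 1 `Fc1cccc(F)c1Cc1cnc(Nc2ccc(Oc3cccnc3)cc2)o1` gives 22000 nM in this assay, the highest of the two numbers, and so the least toxic so far. For the measured compounds named here, compound 2 `Fc1cccc(F)c1Cc1cnc(Nc2ccc(Oc3cccnc3)c(Br)c2)o1` gives 7500 nM in this assay, and the only measured step, a 2.9-fold lower number from compound 1 to compound 2 (0.47 log units; beyond the scatter), came from placing bromo in place of hydrogen on an aromatic carbon. Compound 3 `Fc1cccc(F)c1Cc1cnc(Nc2ccc(COCc3ccco3)cc2)o1` has not yet been measured. It differs from compound 1 in one place: ((furan-2-yl)methoxy)methyl in place of (pyridin-3-yl)oxy on an aromatic carbon. Going by the values given here, no measured step covers this kind of exchange; the step from compound 1 to compound 2 touches a different position and a different group, so it only shows how far a single change on this ring has moved the number. For compound 3 the expectation is therefore a step of a 1.4-fold lower number from compound 1 to compound 3 (0.14 log units; within the scatter), within the scatter. Compound 3 is estimated at 16000 nM in this assay, with a likely range from 5000 nM to 45000 nM.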

Compound 3, half-maximal cytotoxic concentration: 31000 nM
Compound 3: the middle estimate sits 1.9-fold (0.29 log units) below what was measured; the measured number falls inside the stated range.
By their numbers in this assay, from the lowest: compound 2; then compounds 1 and 3 (each within the scatter of the next).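

In this assay, the carbon para to a large group takes ((furan-2-yl)methoxy)methyl in place of (pyridin-3-yl)oxy with a 1.4-fold higher number from compound 1 to compound 3 (0.15 log units; within the scatter), so this exchange of one ring-bearing group for another does not separate compound 1 from compound 3. The earlier pair showed only that adding bromo to this ring can shift the number; this pair shows that the group at this position can be replaced entirely, including its aromatic ring, with no step beyond the scatter. No accompanying measurement accounts for this result.

Going by these compounds, it remains open whether an amine or a carboxylic acid on this same carbon would also stay within the scatter of compound 1. Also open, on these data alone, is whether bromo on the ring of compound 3 would give a step like a 2.9-fold lower number from compound 1 to compound 2 (0.47 log units; beyond the scatter).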